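Aminophenyl ketone on a boron-containing core

The source may report more compounds than this note shows. Statements on the series, on what has been measured and on what is new or still open speak of the compounds shown alone.

The compounds share a core in which a boron-containing ring is linked through a double-bonded chain carbon to a ketone. Compound 1 `O=C(/C=C/c1ccc2c(c1)B(O)OC2)c1ccccn1` carries a pyridin-2-yl group on that carbonyl carbon. In an ADME assay on L929 cells (Mus musculus) for cytotoxicity, read by resazurin assay, with a stated time of 72 h (a higher number here means a weaker inhibitor, a lower number a stronger inhibitor), compound 1 gives > 10 ug/mL, which is a limit of the assay and not a number. Compound 2 `O=C(/C=C/c1ccc2c(c1)B(O)OC2)c1ccc(Cl)c(Cl)c1` carries a different group on the carbonyl carbon. In this assay compound 2 gives > 10 ug/mL, again a limit rather than a number. Compound 1 thus stands at the limit of > 10 ug/mL in this assay, at which 2 of the 2 values shown sit.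

Compound 3 `Nc1cccc(C(=O)/C=C/c2ccc3c(c2)B(O)OC3)c1` is not yet measured; it differs from compound 1 by 3-aminophenyl in place of pyridin-2-yl on a carbonyl carbon. Among the compounds with values here, no step between two measured compounds is available, so the change is judged from the limits alone. The step from compound 1 to compound 3 is expected to be a step that the limit leaves unreadable from compound 1 to compound 3, meaning no shift beyond the usual scatter. Compound 3 is estimated to give 15 ug/mL in this assay, within a range from 6 ug/mL to 40 ug/mL, and the result may again be reported only as a limit.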

Compound 3, half-maximal inhibitory concentration: 10 ug/mL
The estimate for compound 3 lay 1.5-fold (0.18 log units) above the measured number, and the stated range covers the measured number.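

With 3-aminophenyl on the carbonyl carbon, this position gives the only true number among the compounds shown: in this assay, compound 3 gives 10 ug/mL. The change from pyridin-2-yl to 3-aminophenyl gives a number no higher from compound 1 to compound 3 (the limit leaves the size open), so it sets a direction, but its size cannot be read. The other compounds remain at a limit rather than a number: the limit of > 10 ug/mL in this assay, at which 2 of the 3 values shown sit.

The compounds shown leave open how far compound 1 actually lies from compound 3, and whether the amine or the carbon-only ring accounts for the step. A plain phenyl group on the same carbonyl carbon would separate those two parts of the change, and a carboxylic acid in place of the amine would test what the amine contributes.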